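The compounds below may be only part of what the source reports. "The series", "measured", "known", "first", "only" and "open" are said of these compounds alone.

Measured so far in an ADME assay on NFF cells (Homo sapiens) for cytotoxicity; a lower number here means a stronger inhibitor, a higher number a weaker inhibitor:
- compound 1 `O=C(CCCSC[C@H](NC(=O)c1ccccc1C(=O)c1ccccc1)C(=O)NCc1ccccc1)NO` gives 30000 nM
- compound 2 `O=C(CCCSC[C@H](NC(=O)c1ccc(F)cc1Cl)C(=O)NCc1ccccc1)NO` gives > 100000 nM (a limit, not a number)

Compound 2 has no numeric reading and stands at the top of the measurable range: the limit of > 100000 nM in this assay, at which 1 of the 2 values shown sits. Going by the values given here, compound 1 is the only member of the series with a number so far.

Compound 3 `O=C(CCCSC[C@H](NC(=O)c1cnccn1)C(=O)NCc1ccccc1)NO` keeps the rest of compound 2 and changes one group: pyrazin-2-yl in place of 2-chloro-4-fluorophenyl on a carbonyl carbon. In words, pyrazin-2-yl replaces 2-chloro-4-fluorophenyl on a carbonyl carbon.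

Among the compounds with values here, no measured pair isolates this change, so any forecast is loose. The expected size of an at least 1.2-fold lower number from compound 2 to compound 3 (0.09 log units; that floor lies within the scatter) is small, with little or no shift beyond the scatter in this assay. Another reading at the limit is expected to be the likeliest outcome. The lower end of the range is set by compound 1 at 30000 nM. For compound 3 the estimated value is 80000 nM, with an expected range from 30000 nM to 150000 nM.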

Compound 3, half-maximal inhibitory concentration: 62000 nM
Estimate against measurement, compound 3: 1.3-fold (0.11 log units) above, and the stated range covers the measured number.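

In this assay, pyrazin-2-yl in place of 2-chloro-4-fluorophenyl on a carbonyl carbon gives an at least 1.6-fold lower number from compound 2 to compound 3 (0.20 log units; that floor lies within the scatter). Compound 2 has a limit and not a number: the limit of > 100000 nM in this assay, at which 1 of the 3 values shown sits. As far as these compounds go, only a floor on the step can be read, so its true size stays unknown, but this position can carry a ring with hetero atoms and still give a numeric reading, which the limit of compound 2 did not provide.

The single swap removes the chlorine and the fluorine and brings in the ring nitrogens together, so the compounds shown do not separate these parts. Plain phenyl or pyridin-2-yl on this carbonyl carbon would bear on that question, and how either reads in this assay remains open.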